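A few compounds are considered here, and "the series" means these few. Any claim that something is new, unique, unknown or untested is made for them only; others in the source may bear on it.

Compound 1 `c1ccc(Sc2ncnc3[nH]cnc23)cc1` sits at the bottom of the small set measured in an assay on isolated protein for inhibition of Ca2+/calmodulin-dependent protein kinase II (CaM kinase II) (Rattus norvegicus), tested at 30 uM; a lower number here means less inhibition, a higher number more inhibition at the concentration tested (going by the name of the read-out): compound 1 gives 0%. Compound 2 `Fc1ccc(Sc2ncnc3[nH]cnc23)cc1`, which carries fluoro in place of hydrogen on an aromatic carbon, gives 0% in this assay, and the step of no change at the digits printed from compound 1 to compound 2 (within the scatter). Among the measured compounds shown here, the third measured compound, compound 3 `Nc1ncnc2ncn(Cc3ccc(F)cc3)c12`, gives 8% in this assay, a number that lies within the scatter of the value of compound 1; no single-place step connects compound 3 to compound 1, so only the two values themselves can be compared.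

Compound 4 `c1ccc(Cn2cnc3c(Sc4ccccc4)ncnc32)cc1` is yet to be measured in this assay. It differs from compound 1 in one place: benzyl in place of hydrogen on an aromatic nitrogen. For the measured compounds named here, the only measured single-place step, the one from compound 1 to compound 2, concerns a fluoro on an aromatic carbon and so says nothing about a benzyl entering on a ring nitrogen. Compound 3 does carry a benzyl on a ring nitrogen of the shared core, but it differs from compound 1 elsewhere too, so no step can be read from it. With every measured number at or near zero, the step from compound 1 to compound 4 is expected to be a number 5 percentage points higher from compound 1 to compound 4 (within the scatter), no change beyond the scatter. Compound 4 is therefore estimated at 5% in this assay, within a range from 0% to 20%.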

Compound 4, a percentage reported as inhibition, at one concentration (the size of the read-out at that concentration, not a potency): 3%
Compound 4: middle estimate off by 2 percentage points, on the high side; the measured number falls inside the stated range.
By their numbers in this assay, from the lowest: compounds 1, 2, 4 and 3 (each within the scatter of the next).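

In this assay, benzyl in place of hydrogen on an aromatic nitrogen gives a number 3 percentage points higher from compound 1 to compound 4 (within the scatter) and so leaves the read-out where it was. Among the compounds shown here, this is the first single-place step at the ring nitrogen of the five-membered aromatic ring, and it shows that a group of this size, with one six-membered aromatic ring of carbon only, can enter there without the inhibition read-out moving beyond the scatter. The earlier step concerned only a fluoro on an aromatic carbon, so it could not show this, and nothing measured here speaks to the reason for the result.

Since compound 1 gives 0% in this assay, a change that lowers the read-out could not show itself from this starting point, and the step tells only that benzyl brings no rise beyond the scatter at the concentration tested. Open too, as far as these compounds go, is whether an amine, a carboxylic acid or a longer chain on that ring nitrogen would behave as benzyl does, or whether any group there can lift the read-out clear of the scatter.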